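The compounds below may be only part of what the source reports. "The series", "measured", "known", "first", "only" and "open" are said of these compounds alone.

Measured so far in an assay on isolated protein for inhibition of Fatty-acid amide hydrolase 1 (Homo sapiens), read by fluorescence, with a stated time of 30 min; on this read-out higher numbers stand for weaker inhibition and lower numbers for stronger inhibition:
- compound 1, `CCOC(=O)c1cc(-c2ccc(OC(=O)NC3CCCCC3)cc2)n(-c2ccccc2)n1`: 268 nM
- compound 2, `NC(=O)c1cc(-c2cccc(OC(=O)NC3CCCCC3)c2)n(-c2ccccc2)n1`: 169 nM

Of the two numbers, compound 2's is the smaller, but the gap to compound 1 falls within the usual scatter, so the two compounds stand level in this assay and no order between them is claimed.

Compound 3, `COc1ccc(-n2nc(C(N)=O)cc2-c2cccc(OC(=O)NC3CCCCC3)c2)cc1`, differs from compound 2 by methoxy in place of hydrogen on an aromatic carbon. For the measured compounds named here, no pair among the measured compounds shows this same change, so there is no measured step to lean on. With nothing to indicate otherwise, the change from compound 2 to compound 3 is expected to stay within the scatter in either direction, a 1.1-fold lower number from compound 2 to compound 3 (0.02 log units; within the scatter). On that basis compound 3 is estimated to give 160 nM in this assay, with a range of 55 nM to 470 nM, pending the measurement.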

Compound 3, half-maximal inhibitory concentration: 743 nM
The estimate for compound 3 lay 4.6-fold (0.67 log units) below the measured number; measured number above the stated range.
By their numbers in this assay, from the lowest: compounds 2 and 1 (each within the scatter of the next); then compound 3.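

In this assay, for the compounds shown here, methoxy in place of hydrogen on an aromatic carbon, para to a large group, gives a 4.4-fold higher number from compound 2 to compound 3 (0.64 log units; beyond the scatter) as the first reading at this position. The change from phenyl to 4-methoxyphenyl is therefore not neutral here, which compounds 1 and 2 could not show, as they stand level and carry no substituent at this position. No measurement at hand accounts for the weaker inhibition in compound 3.

On these data alone, it remains open whether the step belongs to methoxy in particular, or whether fluoro, methyl or hydroxy at the same place would give a step of similar size. Also open, as far as these compounds go, is whether the same change would give a similar step on the ethyl ester of compound 1, or with the carbamate-bearing ring substituted as in that compound.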